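Hexyl for trifluoromethyl on the anilino ring of the core

The compounds below may be only part of what the source reports. "The series", "measured", "known", "first", "only" and "open" are said of these compounds alone.

Compound 2 `Cc1nc2c(s1)C(=O)C=C(Nc1ccc(C(F)(F)F)cc1)C2=O` carries a trifluoromethyl on the anilino ring. In a functional assay on HepG2 cells (Homo sapiens) for cytotoxicity, read by MTT assay (a lower number here means a stronger inhibitor, a higher number a weaker inhibitor), compound 2 gives > 100 ug/mL, which is a limit of the assay and not a number. Among the values shown, compound 2 sits at the limit of > 100 ug/mL in this assay, at which 1 of the 3 values shown sits. Within the data shown here, the one closely related measured compound is compound 1 `CCOc1ccc(NC2=CC(=O)c3sc(C)nc3C2=O)cc1`, which in this assay gives 4.9 ug/mL. Compound 3 `COC1=CC(=O)c2ncsc2C1=O` in this assay gives "not tested" (no result reported). Among the measured compounds shown here, the single measured step, an at least 20-fold higher number from compound 1 to compound 2 (1.30 log units; beyond the scatter), shows that exchanging ethoxy for trifluoromethyl on that aromatic carbon moves the number well beyond the scatter towards weaker inhibition.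

Compound 4 `CCCCCCc1ccc(NC2=CC(=O)c3sc(C)nc3C2=O)cc1` differs from compound 2 as follows: hexyl in place of trifluoromethyl on an aromatic carbon. For the measured compounds named here, no measured step covers hexyl on this position, and the only step available concerns trifluoromethyl against ethoxy, so it bears on compound 4 merely by showing that the substituent at this aromatic carbon can shift the number by a large amount. Because compound 2 stands at > 100 ug/mL, a limit, the direction of the step to compound 4 cannot be read from the data, and a wide range is expected. The step of an at least 3.3-fold lower number from compound 2 to compound 4 (0.52 log units; beyond the scatter) is estimated as a return towards the region of compound 1, with considerable uncertainty. For compound 4 the expected value in this assay is 30 ug/mL, between 6 ug/mL and 150 ug/mL.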

Compound 4, half-maximal inhibitory concentration: 22 ug/mL
For compound 4 the middle estimate is 1.4-fold (0.13 log units) above the measured one, within the range that was stated.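

In this assay, hexyl in place of trifluoromethyl gives an at least 4.5-fold lower number from compound 2 to compound 4 (0.65 log units; beyond the scatter), so the weak result of compound 2 does not extend to every replacement of ethoxy on this aromatic carbon. Hexyl in place of ethoxy still gives a 4.5-fold higher number from compound 1 to compound 4 (0.65 log units; beyond the scatter), which places hexyl between the other two groups in this small set, with both steps beyond the scatter and the earlier single step now joined by a second substituent comparison at the same carbon. The value of compound 2 is a limit and not a number, so the step from it fixes only a minimum size and the true gap between trifluoromethyl and hexyl stays unknown: the limit of > 100 ug/mL in this assay, at which 1 of the 4 values shown sits.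

With only ethoxy, trifluoromethyl and hexyl at this aromatic carbon, the compounds shown do not tell whether an amine or a carboxylic acid there would give a number inside or outside this span. On these data alone, it also remains open whether a butyl or an octyl chain would move the number further in either direction from hexyl, as a single chain length gives no trend with chain length.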